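Carboxymethyl for carboxymethoxy on the shared core

This account rests on a few compounds, and the source may have more. Where it says the series, first, only, none or still open, it means among the compounds named here.

Compound 3 `O=C(O)COCc1nc(Nc2ccc(C(F)(F)F)cc2)c2ccc(-c3ncccc3C(F)(F)F)cc2n1` carries a carboxymethoxy group at the saturated chain carbon on the shared core, and in a functional assay for antagonist activity at transient receptor potential cation channel subfamily V member 1 (Homo sapiens) (a lower number here means a stronger inhibitor, a higher number a weaker inhibitor), compound 3 gives 81 nM, the highest of the three numbers recorded. The parent, compound 1 `COCc1nc(Nc2ccc(C(F)(F)F)cc2)c2ccc(-c3ncccc3C(F)(F)F)cc2n1`, gives 1.5 nM in this assay, and the phosphate analogue compound 2 `O=P(O)(O)OCc1nc(Nc2ccc(C(F)(F)F)cc2)c2ccc(-c3ncccc3C(F)(F)F)cc2n1` gives 46 nM. The move from the methyl ether to either acidic group is large: a 54-fold higher number from compound 1 to compound 3 (1.73 log units; beyond the scatter) and a 31-fold higher number from compound 1 to compound 2 (1.49 log units; beyond the scatter). Between the two acids the gap is small: a 1.8-fold higher number from compound 2 to compound 3 (0.25 log units; within the scatter).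

Compound 4 `O=C(O)CCc1nc(Nc2ccc(C(F)(F)F)cc2)c2ccc(-c3ncccc3C(F)(F)F)cc2n1` is made from compound 3 by the change (carboxymethyl in place of carboxymethoxy on a saturated chain carbon bound to an aromatic carbon). The acid is kept; only the ether oxygen of the linker is removed, so the chain shortens by one atom. Among the measured compounds shown here, the steps that bear on this are those involving the acid-bearing compounds: the step from compound 1 to compound 3 shows that a carboxy on the chain brings a large rise in the number, and the step from compound 2 to compound 3 shows that two different acidic groups on the same oxygen sit within the scatter of each other. Nothing recorded tells what removing the ether oxygen while keeping the acid does.

Compound 4 is therefore expected to remain near compound 3, with a step of a 1.2-fold lower number from compound 3 to compound 4 (0.06 log units; within the scatter) that stays within the scatter. In this assay compound 4 is estimated at 70 nM, with a range from 25 nM to 200 nM.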

Compound 4, half-maximal inhibitory concentration: 1630 nM
For compound 4 the middle estimate is 23-fold (1.37 log units) below the measured one; the whole stated range lies below it.
By their numbers in this assay, from the lowest: compound 1; then compounds 2 and 3 (each within the scatter of the next); then compound 4.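

In this assay the acid alone does not set the number at this position: with the carboxylic acid kept, carboxymethyl in place of carboxymethoxy on a saturated chain carbon bound to an aromatic carbon gives a further large rise (a 20-fold higher number from compound 3 to compound 4 (1.30 log units; beyond the scatter)). The earlier compounds shown here showed the two acidic groups on the same oxygen within the scatter of each other, but compound 4 stands clearly apart from both the phosphate and the parent methyl ether (a 35-fold higher number from compound 2 to compound 4 (1.55 log units; beyond the scatter); a 1100-fold higher number from compound 1 to compound 4 (3.04 log units; beyond the scatter)), so the chain that carries the acid counts as well as the acid itself. Nothing available explains the size of these steps.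

The compounds shown do not tell whether the rise follows from losing the ether oxygen or from the shorter chain, since the change does both at once, and a longer chain ending in a carboxylic acid with no ether oxygen would separate the two. Nor do they show what a plain ethyl group or an amine on this chain carbon would give, with no acid present.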